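The compounds below may be only part of what the source reports. "The series", "measured", "known", "first", "only" and "open" are said of these compounds alone.

Measured in a functional assay on cells for antagonist activity at Orexin receptor type 2 (Homo sapiens), read by FLIPR and calcium flux; a higher number here means a weaker inhibitor, a lower number a stronger inhibitor:

Compound 1 `COc1ccc(C(=O)N2C[C@H](Oc3nccc(C#N)c3C)CC[C@H]2C)c(-n2nccn2)n1`, 21 nM
Compound 2 `Cc1c(C#N)ccnc1O[C@@H]1CC[C@@H](C)N(C(=O)c2ccccc2C(F)(F)F)C1`, 21 nM
Compound 3 `CC(=O)Nc1cc(C(=O)N2C[C@H](Oc3nccc(C#N)c3C)CC[C@H]2C)c(-c2ccccc2)cn1`, 38 nM

Where compound 2 stands. On the numbers in this assay, compound 2 is level with compound 1 at the digits shown, and the two share the lowest value of the three. The gap from compound 2 to compound 3 is the furthest, and it too lies within the scatter of repeated measurement, so the three measured compounds cannot be separated by this assay.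

The step to compound 4. Compound 4 `CCOc1ccccc1C(=O)N1C[C@H](Oc2nccc(C#N)c2C)CC[C@H]1C` is compound 2 with one change: ethoxy in place of trifluoromethyl on an aromatic carbon. Among the measured compounds shown here, no measured pair in the set differs in just this way, so the size of the step has to be estimated rather than read off. The set gives no ground for a change beyond the scatter in either direction; the expectation is a value close to that of compound 2, with the range widened to allow for the untested change.

Estimate. Compound 4 is expected at 30 nM in this assay, within 8 nM to 120 nM, which means an expected step of a 1.4-fold higher number from compound 2 to compound 4 (0.15 log units; within the scatter).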

Compound 4, half-maximal inhibitory concentration: 6 nM
The estimate for compound 4 lay 5.0-fold (0.70 log units) above the measured number, and the stated range ends above it.
By their numbers in this assay, from the lowest: compound 4; then compounds 1, 2 and 3 (each within the scatter of the next).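

Ethoxy in place of trifluoromethyl on an aromatic carbon, ortho to a large group, gives in this assay a 3.5-fold lower number from compound 2 to compound 4 (0.54 log units; beyond the scatter) and so provides the first single-place step in the series, and the first gap between compared compounds that stands clear of the scatter. Compounds 1, 2 and 3 could not be separated, whereas this pair shows that the group at this position can move the number in this assay and that trifluoromethyl is not required there for a low value. The change swaps a group with no hydrogen-bond acceptor for one with a single acceptor and one fewer heavy atom, but nothing on hand ties the gain to either difference or to any other cause.

Still open, from the compounds shown here alone, is how the number responds to other groups at this position, such as methoxy, a longer chain like propoxy, a hydroxyl or an amine, which would show whether the ether oxygen or the chain length tracks with the gain. Going by these compounds, it is also open whether ethoxy brings a similar step on the aromatic rings of compound 1 or compound 3, which differ from compound 4 in more than one place.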